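Methoxy to trifluoromethyl on the quinolone core: cytotoxicity notes

This account rests on a few compounds, and the source may have more. Where it says the series, first, only, none or still open, it means among the compounds named here.

Measured compounds:
compound 1 `CNCC1(C)CCN(c2c(F)cc3c(=O)c(C(=O)O)cn(C4CC4)c3c2OC)C1`, 120 ug/mL
compound 2 `CNCC1(C)CCN(c2c(F)cc3c(=O)c(C(=O)O)cn(C4CC4)c3c2C(F)(F)F)C1`, 230 ug/mL
compound 3 `COc1c(N2CC(C)NC(C)C2)c(F)cc2c(=O)c(C(=O)O)cn(C3CC3)c12`, limit > 500 ug/mL

In a functional assay on V79 cells (Cricetulus griseus) for cytotoxicity, read by colony formation (on this read-out higher numbers stand for weaker inhibition and lower numbers for stronger inhibition), compound 1 gives 120 ug/mL. Compound 2 carries the change trifluoromethyl in place of methoxy on an aromatic carbon and the step of a 1.9-fold higher number from compound 1 to compound 2 (0.28 log units; within the scatter). Compound 3 differs from compound 1 by 3,5-dimethylpiperazin-1-yl in place of 3-methyl-3-((methylamino)methyl)pyrrolidin-1-yl on an aromatic carbon. In this assay compound 3 gives > 500 ug/mL, which is a limit of the assay, not a number, as the limit of > 500 ug/mL in this assay, at which 1 of the 3 values shown sits, shows. The step of an at least 4.1-fold higher number from compound 1 to compound 3 (0.61 log units; beyond the scatter) is therefore a lower bound only.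

Compound 4 `CC1CN(c2c(F)cc3c(=O)c(C(=O)O)cn(C4CC4)c3c2C(F)(F)F)CC(C)N1` is not yet measured. It arises from compound 3 through (trifluoromethyl in place of methoxy on an aromatic carbon), the same kind of change as from compound 1 to compound 2, though here the place is ortho to a 3,5-dimethylpiperazin-1-yl group (8 heavy atoms) rather than ortho to a 3-methyl-3-((methylamino)methyl)pyrrolidin-1-yl group (9 heavy atoms). Given that compound 1 to compound 2 moved only a 1.9-fold higher number from compound 1 to compound 2 (0.28 log units; within the scatter), the expected step for compound 4 is a step that the limit leaves unreadable from compound 3 to compound 4, starting from a limit. Compound 4 is therefore estimated at 900 ug/mL, most likely again reported only as a limit.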

Compound 4, half-maximal inhibitory concentration: > 500 ug/mL
Compound 4 ended at the assay's limit (the forecaster's own chance of this, stated with the estimate: 80%); the middle value lies beyond the limit too.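

The step from compound 3 to compound 4 cannot be read, as both values in this assay are limits of the assay. On the core of compound 2, 3,5-dimethylpiperazin-1-yl in place of 3-methyl-3-((methylamino)methyl)pyrrolidin-1-yl gives an at least 2.1-fold higher number from compound 2 to compound 4 (0.33 log units; beyond the scatter). Carried between the two cores, this change keeps its direction, but its size on each core is not fixed and no difference between the cores can be claimed: the same change on two cores in this assay, an at least 4.1-fold higher number (0.61 log units; beyond the scatter) from compound 1 to compound 3 and an at least 2.1-fold higher number (0.33 log units; beyond the scatter) from compound 2 to compound 4; the limit leaves it open whether they differ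

As far as these compounds go, it remains open whether trifluoromethyl in place of methoxy behaves with 3,5-dimethylpiperazin-1-yl as it does with the pyrrolidine side chain of compound 1 and compound 2. Also open, from the compounds shown here alone, is how a chloro group or a methyl group on the same aromatic carbon would read.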